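The source may hold more compounds than are shown below. What is called first, only, known or untested is meant among the compounds shown, and "the series" means these compounds.

Working notes on the series. Compound 1 `COc1ccccc1-c1nc(Cc2c[nH]c3ccccc23)no1` and compound 2 `COc1cccc(-c2nc(Cc3c[nH]c4ccccc34)no2)c1` share a core with compound 3 `COc1ccc(-c2nc(Cc3c[nH]c4ccccc34)no2)c(OC)c1`; in a functional assay on cells (Splenocyte, Mus musculus, strain BALB/c) for inhibition, read by scintillation counting and thymidine incorporation, with stated times of 48 h and 8 h (a lower number here means a stronger inhibitor, a higher number a weaker inhibitor), compound 1 gives 11100 nM, compound 2 gives 11100 nM and compound 3 gives 4700 nM. Compound 2 thus stands level with compound 1, the two together the highest of the three numbers, while compound 3 sits below both. Within the data shown here, the one measured step, a 2.4-fold lower number from compound 1 to compound 3 (0.37 log units; beyond the scatter), adds a methoxy to a ring that already carries one. Compound 4 `COc1ccc(OC)c(-c2nc(Cc3c[nH]c4ccccc34)no2)c1` repeats that kind of change on compound 2: methoxy in place of hydrogen on an aromatic carbon. Taking the step from compound 1 to compound 3 as the only guide, a modest lowering is expected, a 2.0-fold lower number from compound 2 to compound 4 (0.30 log units; within the scatter). Compound 4 is therefore estimated at 5500 nM, with a range of 2500 nM to 12000 nM.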

Compound 4, half-maximal inhibitory concentration: 8400 nM
Estimate against measurement, compound 4: 1.5-fold (0.18 log units) below; low and high end bracket the measured number.
By their numbers in this assay, from the lowest: compounds 3, 4, 1 and 2 (each within the scatter of the next, the first and the last beyond it).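

In this assay, a methoxy ortho to a large group and para to a methoxy group gives a 1.3-fold lower number from compound 2 to compound 4 (0.12 log units; within the scatter), and the same change read from the other parent gives a 1.3-fold lower number from compound 1 to compound 4 (0.12 log units; within the scatter). At this position, then, the change produces no step beyond the scatter, unlike the step to compound 3, yet the two cores cannot be told apart on this change: the same change on two cores in this assay, a 2.4-fold lower number (0.37 log units; beyond the scatter) from compound 1 to compound 3 and a 1.3-fold lower number (0.12 log units; within the scatter) from compound 2 to compound 4, 1.8-fold (0.25 log units) apart, within the scatter of two such steps. Still open, from the compounds shown here alone, is whether an amine or a carboxylic acid at this position, in place of the methoxy, would give a step beyond the scatter.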